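The compounds below may be only part of what the source reports. "The series", "measured", "known", "first", "only" and "open" are said of these compounds alone.

Compound 1, with structure `CCC(c1nc2ncc(Cl)cc2[nH]1)[C@H]1CC[C@@H](c2ccnc3ccc(C(F)(F)F)cc32)CC1`, is the most potent of the three compounds measured in an assay on tissue (HeLa cells) for inhibition of Indoleamine 2,3-dioxygenase 1 (Homo sapiens), read by fluorescence, with a stated time of 18 h (a lower number here means a stronger inhibitor, a higher number a weaker inhibitor), where compound 1 gives 2 nM. Compound 2, with structure `CCC(Nc1nnc(-c2ccc(OC)cc2)o1)[C@H]1CC[C@@H](c2ccnc3c(F)cc(F)cc32)CC1`, gives 3 nM in this assay, a number within the usual scatter of that of compound 1, so the two cannot be ranked against each other. Compound 3, with structure `C[C@@H](c1ncc(-c2ccc(Cl)cc2)o1)[C@H]1CC[C@@H](c2ccnc3ccc(F)cc32)CC1`, gives 495 nM, a far weaker result that lies well beyond the scatter, but compound 3 differs from compound 1 in several places at once, so its number says nothing about any single change.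

Compound 4, with structure `CCC(c1nc2ncc(Cl)cc2[nH]1)[C@H]1CC[C@@H](c2ccnc3ccc(F)cc32)CC1`, has not been measured. It differs from compound 1 in one place: fluoro in place of trifluoromethyl on an aromatic carbon. Going by the values given here, no measured pair of compounds isolates this exact change, so the expectation rests on compound 1 and compound 2 alone, which both carry fluorine-bearing cores. In this assay compound 1 gives 2 nM, and compound 2 gives 3 nM. A modest loss, or none beyond the scatter, is expected, corresponding to an estimated step of a 2.5-fold higher number from compound 1 to compound 4 (0.40 log units; beyond the scatter). Compound 4 is therefore estimated at 5 nM, with a likely range from 1.5 nM to 20 nM.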

Compound 4, half-maximal inhibitory concentration: 2 nM
Beside the measured number, compound 4's estimate is 2.5-fold (0.40 log units) above it; the measured number falls inside the stated range.
By their numbers in this assay, from the lowest: compounds 1, 4 and 2 (each within the scatter of the next); then compound 3.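

In this assay, the replacement of trifluoromethyl by fluoro on this aromatic carbon gives no change at the digits printed from compound 1 to compound 4 (within the scatter), and this is the first pair shown that isolates a change at this position. The group shrinks from 4 heavy atoms to 1 heavy atom, yet the number stays within the scatter, so with this side chain the position accepts either group without a measurable penalty. Nothing measured here explains why the two groups read alike.

As far as these compounds go, what an amine, a carboxylic acid or a plain hydrogen on this carbon would do remains open, so it is unknown whether any fluorine-bearing group is needed there. From the compounds shown here alone, it is also open whether the same swap would read alike on the other side chains, such as those of compound 2 and compound 3.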